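Swapping Fluoro for Trifluoromethyl on the Second Aryl Ring

The compounds below may be only part of what the source reports. "The series", "measured", "known", "first", "only" and "open" are said of these compounds alone.

Compound 1 `O=C(O)C[C@H](O)C[C@H](O)CCn1c(C(F)(F)F)nc(-c2ccc(F)cc2)c1-c1ccc(F)cc1` gives 38 nM in an assay on microsomes from liver for inhibition of 3-hydroxy-3-methylglutaryl-coenzyme A reductase (Rattus norvegicus); a higher number here means a weaker inhibitor, a lower number a stronger inhibitor. Among the three measured compounds it stands close to compound 3 `Cc1cc(-c2nc(C(F)(F)F)n(CC[C@@H](O)C[C@@H](O)CC(=O)O)c2-c2ccc(F)cc2)cc(C)c1F`, which gives 32 nM, a difference within the scatter, and well apart from compound 2 `O=C(O)C[C@H](O)C[C@H](O)CCn1c(C(F)(F)F)nc(-c2ccc(C(F)(F)F)cc2)c1-c1ccc(F)cc1`, which gives 200 nM; that step is a 5.3-fold higher number from compound 1 to compound 2 (0.72 log units; beyond the scatter). Compound 4 `O=C(O)C[C@H](O)C[C@H](O)CCn1c(C(F)(F)F)nc(-c2ccc(F)cc2)c1-c1ccc(C(F)(F)F)cc1` has not yet been measured. It differs from compound 1 by trifluoromethyl in place of fluoro on an aromatic carbon, the same exchange that compound 2 carries, but placed on the other of the two fluorophenyl rings. Because a 5.3-fold higher number from compound 1 to compound 2 (0.72 log units; beyond the scatter) weakened inhibition, a weakening of similar size is expected here as well, with added uncertainty since a different ring is changed. Compound 4 is therefore estimated at 120 nM, between 40 nM and 400 nM. The expected step is a 3.2-fold higher number from compound 1 to compound 4 (0.50 log units; beyond the scatter).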

Compound 4, half-maximal inhibitory concentration: > 1000 nM
Compound 4: only a limit was reported (the forecaster's own chance of this, stated with the estimate: 2%); middle value at least 8.3-fold (0.92 log units) away from the limit.
By their numbers in this assay, from the lowest: compounds 3 and 1 (each within the scatter of the next); then compound 2. At a limit, above all of these: compound 4.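

The exchange of fluoro for trifluoromethyl does not carry the same cost on the two fluorophenyl rings. On this ring it gives an at least 26-fold higher number from compound 1 to compound 4 (1.42 log units; beyond the scatter), whereas on the other ring it gives a 5.3-fold higher number from compound 1 to compound 2 (0.72 log units; beyond the scatter). Compound 4 is reported only as a limit: the limit of > 1000 nM in this assay, at which 1 of the 4 values shown sits.

From the compounds shown here alone, whether a methyl group or a chlorine atom at this position would keep inhibition close to that of compound 1 remains open. So does how a methoxy group or an amine would behave there.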